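Fluoro replaced by hydrogen in compound 4

A few compounds are considered here, and "the series" means these few. Any claim that something is new, unique, unknown or untested is made for them only; others in the source may bear on it.

Going by the values given here, compound 3 `Fc1cccc(-c2n[nH]cc2N2CCCNCC2)c1` gives 2540 nM in an assay on isolated protein for binding affinity to 5-hydroxytryptamine receptor 1D (Homo sapiens) (on this read-out lower numbers stand for stronger inhibition and higher numbers for weaker inhibition), the second highest of the three numbers measured so far. Compound 1 `Cc1cccc(-c2n[nH]cc2N2CCCNCC2)c1` gives 3290 nM, and compound 2 `Cc1ccc(-c2n[nH]cc2N2CCCNCC2)cc1` gives 892 nM. Compound 4 `c1ccc(-c2n[nH]cc2N2CCCNCC2)cc1` differs from compound 3 by hydrogen in place of fluoro on an aromatic carbon. Among the compounds with values here, no measured step removes a substituent at this position altogether; the only step at the same place, a 1.3-fold lower number from compound 1 to compound 3 (0.11 log units; within the scatter), moved the number very little. On that basis the expected step of a 1.2-fold lower number from compound 3 to compound 4 (0.06 log units; within the scatter) is small and has no clear direction. Compound 4 is therefore estimated at 2200 nM, with a range from 800 nM to 6000 nM. The spread among compound 1, compound 2 and compound 3 is the main source of uncertainty.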

Compound 4, inhibition constant: > 10000 nM
Compound 4 ended at the assay's limit; the forecaster's own chance of this, stated with the estimate: 5%; middle value at least 4.5-fold (0.65 log units) away from the limit.
By their numbers in this assay, from the lowest: compound 2; then compounds 3 and 1 (each within the scatter of the next). At a limit, above all of these: compound 4.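

In this assay, a substituent on this aromatic carbon matters more than the exchange of methyl for fluoro suggested, since hydrogen there gives a clear rise in the number against fluoro (an at least 3.9-fold higher number from compound 3 to compound 4 (0.59 log units; beyond the scatter)) and against methyl (an at least 3.0-fold higher number from compound 1 to compound 4 (0.48 log units; beyond the scatter)). The gap is widest against compound 2 (an at least 11-fold higher number from compound 2 to compound 4 (1.04 log units; beyond the scatter)). All three steps are lower bounds only, as compound 4 sits at a limit and not at a number: (the limit of > 10000 nM in this assay, at which 1 of the 4 values shown sits).

As far as these compounds go, whether chloro or methoxy at this place would lower the number further remains open. So does the outcome for an amine or a carboxylic acid there.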